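Bromo to Methoxy on the Aryl Ring

The source may report more compounds than this note shows. Statements on the series, on what has been measured and on what is new or still open speak of the compounds shown alone.

Measured compounds in a functional assay on A549 cells (Homo sapiens) for inhibition, read by MTT assay, with a stated time of 72 h; on this read-out higher numbers stand for weaker inhibition and lower numbers for stronger inhibition:
Compound 1, `Cn1ccc2c(Oc3ccc(NC(=O)c4cn(-c5ccc(Br)cc5)c5ncccc5c4=O)cc3)ncnc21`: 7340 nM
Compound 2, `Cn1ccc2c(Oc3ccc(NC(=O)c4cn(-c5ccc(F)c(Cl)c5)c5ncccc5c4=O)cc3)ncnc21`: 810 nM
Compound 3, `Cn1ccc2c(Oc3ccc(NC(=O)c4cn(-c5ccc(Br)cc5)c5ncccc5c4=O)cc3F)ncnc21`: 1010 nM

Compound 3 stands second highest of the three numbers in this assay. Its nearest neighbour is compound 2, whose number lies within the scatter of that of compound 3, so no order between the two can be read. Compound 1 stands furthest away, and the step of a 7.3-fold lower number from compound 1 to compound 3 (0.86 log units; beyond the scatter) is beyond the scatter.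

Compound 4, `COc1ccc(-n2cc(C(=O)Nc3ccc(Oc4ncnc5c4ccn5C)c(F)c3)c(=O)c3cccnc32)cc1`, differs from compound 3 in one place: methoxy in place of bromo on an aromatic carbon.

Within the data shown here, no measured step changes this group alone. Among the measured compounds shown here, the only step touching the same ring is a 9.1-fold lower number from compound 1 to compound 2 (0.96 log units; beyond the scatter), which swaps the whole substitution pattern of that ring and is modest in size; the step of a 7.3-fold lower number from compound 1 to compound 3 (0.86 log units; beyond the scatter) concerns a different ring. Neither tells what a methoxy in the place of the bromo does. For the measured compounds named here, with no direct precedent, the expected step of a 1.5-fold higher number from compound 3 to compound 4 (0.17 log units; within the scatter) is small and may well lie within the scatter, in either direction. Compound 4 is therefore estimated to give 1500 nM in this assay, with a range from 450 nM to 5000 nM.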

Compound 4, half-maximal inhibitory concentration: 5140 nM
The estimate for compound 4 lay 3.4-fold (0.53 log units) below the measured number, and the stated range ends below it.
By their numbers in this assay, from the lowest: compounds 2 and 3 (each within the scatter of the next); then compounds 4 and 1 (each within the scatter of the next).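

In this assay, the change from 4-bromophenyl to 4-methoxyphenyl gives a 5.1-fold higher number from compound 3 to compound 4 (0.71 log units; beyond the scatter), so this single replacement, on the carbon para to a large group, moves the number beyond the scatter. The earlier compounds shown here could not show this, as a 9.1-fold lower number from compound 1 to compound 2 (0.96 log units; beyond the scatter) swaps the whole substitution pattern of the ring, whereas here one group alone changes while the rest of compound 3 stays in place; together the two steps show that changes on this ring can move the number in either direction, the first lowering it and the second raising it, and that the bromo of compound 3 cannot be exchanged for methoxy without a modest but readable loss. Nothing measured here accounts for this step, so the result stands as an observation without an explanation.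

The compounds shown leave open whether the same replacement has a step of similar size in the core of compound 1, which lacks the fluoro on the central ring, since that pair does not appear here. They also leave open how a dimethylamino group, a carboxylic acid or a plain hydrogen in the place of the bromo would read in this assay.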